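A few compounds are considered here, and "the series" means these few. Any claim that something is new, unique, unknown or untested is made for them only; others in the source may bear on it.

Of the compounds shown here, three have so far been tested in a functional assay on SK-MEL-28 cells (Homo sapiens) for inhibition, read by MTT assay, with a stated time of 72 h; on this read-out lower numbers stand for stronger inhibition of growth and higher numbers for weaker inhibition of growth. Compound 3 `Clc1ccc(Sc2c(-c3ccc(Cl)cc3)[nH]c3ccccc23)cc1` gives 34000 nM in this assay. Compound 1 `Clc1ccc(Sc2c(-c3ccc(Cl)cc3)[nH]c3ccc(Cl)cc23)cc1` carries chloro in place of hydrogen on an aromatic carbon relative to compound 3, and in this assay compound 1 gives 34000 nM. The step of no change at the digits printed from compound 3 to compound 1 (within the scatter). Compound 2 `OC1CCCN(C(=S)Sc2c(-c3ccc(Br)cc3)[nH]c3ccccc23)C1` rests on a different core, and the difference between the two cores is not broken down here. In this assay compound 2 gives 28000 nM, a number that lies within the scatter of the values of compound 1 and compound 3.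

Compound 4 `OC1CCCN(C(=S)Sc2c(-c3ccc(Br)cc3)[nH]c3ccc(Cl)cc23)C1` has not yet been measured. Relative to compound 2 it carries chloro in place of hydrogen on an aromatic carbon, the same change as the one that turns compound 3 into compound 1, at the same place. Compound 4 is expected to show a step of no change at the digits printed from compound 2 to compound 4 (within the scatter) in this assay, because the same change gave no change at the digits printed from compound 3 to compound 1 (within the scatter). The estimate for compound 4 in this assay is therefore 28000 nM, expected to lie between 14000 nM and 56000 nM.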

Compound 4, concentration for 50% growth inhibition: 34000 nM
Estimate against measurement, compound 4: 1.2-fold (0.08 log units) below, within the range that was stated.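

In this assay, chloro in place of hydrogen on an aromatic carbon of the second core gives a 1.2-fold higher number from compound 2 to compound 4 (0.08 log units; within the scatter). Set beside the earlier step, the change carries from one core to the other with no difference that can be told from the scatter: the same change on two cores in this assay, no change at the digits printed (within the scatter) from compound 3 to compound 1 and a 1.2-fold higher number (0.08 log units; within the scatter) from compound 2 to compound 4, 1.2-fold (0.08 log units) apart, within the scatter of two such steps. Within the data shown here, this shows only that the change leaves the number within the scatter on these two cores; it does not show that the same would hold on any other core, or that a step beyond the scatter would carry over in the same way.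

The compounds shown hold only hydrogen or chloro at this place, so what an amine, a methoxy group or a carboxylic acid there would give in this assay stays open. The two cores also differ in more than one place, and what each of those differences contributes remains unresolved.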